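Reversing the enone linker on a pyrazolopyrimidine-chalcone core

This account rests on a few compounds, and the source may have more. Where it says the series, first, only, none or still open, it means among the compounds named here.

Measured compounds:
compound 1, `COc1ccc(C(=O)/C=C/c2cc(-c3cc(OC)c(OC)c(OC)c3)n3nc(-c4ccccc4)cc3n2)cc1`, 13200 nM
compound 2, `COc1ccc(C(=O)/C=C/c2cc(-c3ccc(OC)c(OC)c3)n3nc(-c4ccccc4)cc3n2)cc1`, 13900 nM

Compound 1 `COc1ccc(C(=O)/C=C/c2cc(-c3cc(OC)c(OC)c(OC)c3)n3nc(-c4ccccc4)cc3n2)cc1` and compound 2 `COc1ccc(C(=O)/C=C/c2cc(-c3ccc(OC)c(OC)c3)n3nc(-c4ccccc4)cc3n2)cc1` share a core and differ only in a 1.1-fold higher number from compound 1 to compound 2 (0.02 log units; within the scatter). In a functional assay on MDA-MB-231 cells (Homo sapiens) for antiproliferative activity, read by MTT assay, with a stated time of 24 h (on this read-out higher numbers stand for weaker inhibition and lower numbers for stronger inhibition), compound 1 gives 13200 nM, and compound 2 gives 13900 nM. Compound 1 thus holds the lower of the two numbers, but the step to compound 2 is within the scatter, so the two cannot be told apart.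

Compound 3 `COc1ccc(/C=C/C(=O)c2cc(-c3cc(OC)c(OC)c(OC)c3)n3nc(-c4ccccc4)cc3n2)cc1` keeps every atom of compound 1 but joins them differently: (2-(4-methoxyphenyl)ethenyl)carbonyl in place of 2-((4-methoxyphenyl)carbonyl)ethenyl on an aromatic carbon. The carbonyl and the double bond of the linker swap places, so the carbonyl now sits on the core and the double bond carries the methoxyphenyl group.

Among the measured compounds shown here, no measured step speaks to this kind of rearrangement; the only step in hand concerns a methoxy group on a different ring and was within the scatter. The expectation for compound 3 therefore rests on the two numbers shown and is wide. Compound 3 is estimated at 12000 nM, between 4000 nM and 40000 nM. This estimate means a step of a 1.1-fold lower number from compound 1 to compound 3 (0.04 log units; within the scatter), expected to stay within the scatter.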

Compound 3, half-maximal inhibitory concentration: 16500 nM
Compound 3: the middle estimate sits 1.4-fold (0.14 log units) below what was measured, and the stated range covers the measured number.
By their numbers in this assay, from the lowest: compounds 1, 2 and 3 (each within the scatter of the next).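

Exchanging the carbonyl and the double bond of the linker, while keeping the same atoms on the same aromatic carbon of the shared core, gives a 1.3-fold higher number from compound 1 to compound 3 (0.10 log units; within the scatter) in this assay. At this position, then, the direction of the enone linker makes no difference that this read-out can resolve. Among the compounds shown here, the earlier pair spoke only to a methoxy group on a different ring, whereas this step is the first to touch the linker itself, and no measurement here explains why the two linker directions read alike.

The compounds shown leave open whether any change at this position can move the number beyond the scatter, for example an amide in place of the enone linker, or a carboxylic acid or an amine in place of the methoxy group on the 4-methoxyphenyl ring. They also leave open whether the two linker directions would still read alike with the 3,4,5-trimethoxyphenyl group replaced by a ring carrying a different group, such as a fluorine or a nitrile.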